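The source may hold more compounds than are shown below. What is called first, only, known or untested is meant among the compounds shown, and "the series" means these compounds.

Measured in a functional assay on FaDu cells (Homo sapiens) for cytotoxicity, read by MTT assay, with a stated time of 72 h; a higher number here means that more compound is tolerated, a lower number that less compound is tolerated:

- compound 1 `CCn1cc(C(=O)C(=O)Nc2ccc(OC)nc2)c2ccccc21`: 219 nM
- compound 2 `COC(=O)CCn1cc(C(=O)C(=O)Nc2ccc(OC)nc2)c2ccccc21`: 168 nM

Among the measured compounds shown here, compound 2, at 168 nM, stands within the scatter of compound 1, the only other compound with a number so far. The next compound, compound 3 `COc1ccc(NC(=O)C(=O)c2cn(CC3CCO3)c3ccccc23)cn1`, keeps the shared core and alters only the chain on the aromatic nitrogen: oxetan-2-yl in place of (methoxycarbonyl)methyl on a saturated chain carbon bound to an aromatic nitrogen. In words, oxetan-2-yl stands in place of (methoxycarbonyl)methyl on a saturated chain carbon bound to an aromatic nitrogen.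

For the measured compounds named here, only one measured step bears on this change. It is a 1.3-fold lower number from compound 1 to compound 2 (0.12 log units; within the scatter), and it also concerns that chain. Going by the values given here, the data hold no compound with a four-membered ring in this chain, so the evidence for compound 3 is indirect. With compound 1 and compound 2 giving no difference beyond the scatter, no step beyond the scatter is expected in this assay, and no direction is favoured.

The expected change is small: a 1.2-fold higher number from compound 2 to compound 3 (0.08 log units; within the scatter). Compound 3 is estimated at 200 nM, with an expected range from 70 nM to 600 nM.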

Compound 3, concentration lethal to 50% of the cells: 686 nM
For compound 3 the middle estimate is 3.4-fold (0.54 log units) below the measured one, outside the stated range (above it).
By their numbers in this assay, from the lowest: compounds 2 and 1 (each within the scatter of the next); then compound 3.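

In this assay, putting oxetan-2-yl in place of (methoxycarbonyl)methyl on a saturated chain carbon bound to an aromatic nitrogen gives a 4.1-fold higher number from compound 2 to compound 3 (0.61 log units; beyond the scatter), and putting it in place of methyl at that same place gives a 3.1-fold higher number from compound 1 to compound 3 (0.50 log units; beyond the scatter), so both steps lie beyond the scatter and point the same way. The chain on the aromatic nitrogen had looked indifferent while only compound 1 and compound 2 could be compared, but compound 3 shows that this position can move the number in this assay, and that the change here is towards more compound being tolerated. Nothing measured in the data accounts for this shift.

On these data alone, it remains open whether the higher number goes with the four-membered ring as such or with the oxygen in it, and whether a cyclobutylmethyl chain, with carbon in place of that ring oxygen, would stand with compound 3 or with compound 1 and compound 2. How an amine or a carboxylic acid at the end of this chain would behave in this assay is equally undecided by these three compounds.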